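Adding a Methyl to the Phenyl Ring of Compound 2

The compounds below may be only part of what the source reports. "The series", "measured", "known", "first", "only" and "open" are said of these compounds alone.

Measured so far in a functional assay on PC-3 cells (Homo sapiens) for inhibition, read by MTT assay, with a stated time of 24 h; on this read-out higher numbers stand for weaker inhibition and lower numbers for stronger inhibition:
Compound 1 `CCCc1cc2ccccc2nc1-c1cc(-c2ccccc2)no1` gives 51300 nM.
Compound 2 `CCCCc1cc2ccccc2nc1-c1cc(-c2ccccc2)no1` gives > 100000 nM, which is a limit of the assay and not a number.
Compound 3 `CCCCCc1cc2ccccc2nc1-c1cc(-c2ccccc2)no1` gives > 100000 nM, again only a limit.

Compound 2 therefore has no measured number of its own; the limit of > 100000 nM in this assay, at which 2 of the 3 values shown sit, marks where it sits. The steps of an at least 1.9-fold higher number from compound 1 to compound 2 (0.28 log units; that floor lies within the scatter) and an at least 1.9-fold higher number from compound 1 to compound 3 (0.28 log units; that floor lies within the scatter) show the readings climbing out of range as the chain on the shared core grows, and the step that the two limits leave unreadable from compound 2 to compound 3 cannot be read at all. Compound 4 `CCCCc1cc2ccccc2nc1-c1cc(-c2ccc(C)cc2)no1` differs from compound 2 by methyl in place of hydrogen on an aromatic carbon. Among the compounds with values here, no measured step touches that ring, so the expected step that the limit leaves unreadable from compound 2 to compound 4 is taken as none beyond the scatter. Compound 4 is thus expected at 150000 nM, within 60000 nM to 400000 nM, most likely reported again as a limit.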

Compound 4, half-maximal inhibitory concentration: > 100000 nM
Compound 4: no number, only a limit; the forecaster's own chance of this, stated with the estimate: 80%; the middle value lies beyond the limit too.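

Within the data shown here, compound 2 and compound 4 both give only limits of the assay, not numbers, and no step between them can be read. From the compounds shown here alone, whether going from phenyl to 4-methylphenyl changes the inhibition at all stays open.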